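This account rests on a few compounds, and the source may have more. Where it says the series, first, only, none or still open, it means among the compounds named here.

Compound 1 `CCCCCCCCCCCCCCCCCCOC[C@H](COP(=O)(O)O[C@@H]1[C@H](O)[C@@H](CO)[C@@H](O)[C@H](O)[C@@H]1O)OC`: 7500 nM
Compound 2 `CCCCCCCCCCCCCCCCCCOC[C@H](COC(=O)O[C@@H]1[C@H](O)[C@@H](CO)[C@@H](O)[C@H](O)[C@@H]1O)OC`: > 20000 nM (a limit)

Both compounds were tested in a functional assay on HeLa cells (Homo sapiens) for inhibition; a lower number here means a stronger inhibitor, a higher number a weaker inhibitor. Compound 1 gives a number, 7500 nM. Compound 2 gives only a limit of the assay, > 20000 nM, and not a number. Among the compounds with values here, the series so far shows (the limit of > 20000 nM in this assay, at which 1 of the 2 values shown sits).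

Compound 3 `CCCCCCCCCCCCCCCCCCOC[C@H](COC(=O)O[C@@H]1[C@H](O)[C@H](CO)[C@@H](O)[C@H](O)[C@@H]1O)OC` is a stereoisomer of compound 2: the two compounds have the same atoms and bonds and differ only in configuration as drawn: 1 of 7 stereo elements differ; a stereocentre at a saturated ring carbon is drawn S in compound 2 and R in compound 3. Within the data shown here, no measured pair shows what a change of configuration does in this assay, so no direction is expected, and no step beyond the scatter is expected. This expectation rests on compound 2, whose limit is > 20000 nM. A report of compound 3 as a limit again would be no surprise. The expected size of the change is a step that the limit leaves unreadable from compound 2 to compound 3. For compound 3 the estimated value is 22000 nM, with an expected range of 9000 nM to 45000 nM.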

Compound 3, half-maximal inhibitory concentration: 2500 nM
Compound 3: middle estimate off by 8.8-fold (0.94 log units), on the high side; measured number below the stated range.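

In this assay a single change of configuration gives an at least 8.0-fold lower number from compound 2 to compound 3 (0.90 log units; beyond the scatter), the first sign in this series that this stereocentre at a saturated ring carbon matters. Nothing else separates the two compounds, so the step belongs to this centre, drawn S in compound 2 and R in compound 3: the fact that compounds 2 and 3 differ only in the configuration as drawn Its full size cannot be read, since compound 2 is reported only as a limit: the limit of > 20000 nM in this assay, at which 1 of the 3 values shown sits.

Still open, from the compounds shown here alone, is whether the R configuration at this carbon keeps its effect when the carbonate linker gives way to a carbamate, or when the lipid tail carries a longer chain. Going by these compounds, the effect of changing the configuration at the other ring stereocentres also remains open.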